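The compounds below may be only part of what the source reports. "The series", "measured", "known", "first", "only" and "open" are said of these compounds alone.

Compound 1, `COc1c(OC)c(OC(=O)C(C)C)c2ccccc2c1OC(=O)C(C)C`, and compound 2, `COc1c(OC)c(OC(=O)C(C)C)c2c(C)cccc2c1OC(=O)C(C)C`, share a core and differ in one place: methyl in place of hydrogen on an aromatic carbon. In a physicochemical assay for lipophilicity (a lower number here means a more polar compound, a higher number a more lipophilic compound), compound 1 gives 4.61, and compound 2 gives 5. The step between them is a number 0.39 log units higher from compound 1 to compound 2 (beyond the scatter).

Compound 3, `CCC(=O)Oc1c(OC)c(OC)c(OC(=O)CC)c2cc(C)ccc12`, is built on a different core; the difference between the two cores is not broken down here. In this assay, going by the values given here, compound 3 gives 3.9, the lowest of the three numbers so far, a value that stands beyond the usual scatter from both compound 1 and compound 2.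

Compound 4, `CCC(=O)Oc1c(OC)c(OC)c(OC(=O)CC)c2cc(C)c(C)cc12`, has not yet been measured. It differs from compound 3 in one place: methyl in place of hydrogen on an aromatic carbon. Among the compounds with values here, this is the same kind of change as the one from compound 1 to compound 2, but the surroundings are not identical: in compound 2 the entering methyl sits ortho to a fused ring and meta to a fused ring, whereas in compound 4 it sits ortho to a methyl group, meta to a fused ring and para to a fused ring. Within this series the change occurs twice in all, and only the first instance is measured.

Within the data shown here, because a number 0.39 log units higher from compound 1 to compound 2 (beyond the scatter) is the only measured guide, compound 4 is expected to show a step of about a number 0.40 log units higher from compound 3 to compound 4 (beyond the scatter) in this assay. On that basis compound 4 is estimated at 4.3, with a range expected from 4 to 4.6.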

Compound 4, partition coefficient: 4.2
Compound 4: the middle estimate sits 0.10 log units above what was measured; the measured number falls inside the stated range.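

In this assay the step on the core of compound 3 is a number 0.30 log units higher from compound 3 to compound 4 (within the scatter), while the same replacement on the core of compound 1 gave a number 0.39 log units higher from compound 1 to compound 2 (beyond the scatter). The methyl in place of hydrogen therefore separates from the usual scatter on one core and not on the other, so the beyond-scatter reading seen on the first core is not reproduced on the second, although the two steps point the same way as printed. With a single pair on each core, and with the entering methyl on the second core standing ortho to a methyl group, meta to a fused ring and para to a fused ring, this neither shows that the change transfers between the cores nor that it fails to, and nothing available here bears on why the two steps read as they do.

The compounds shown leave open how this assay would respond on either core to a different group on that aromatic carbon, such as an amine, a carboxylic acid or a longer chain like ethyl in place of the methyl. They also leave open whether further methyl pairs on these cores would fall within the scatter or beyond it.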